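The source may report more compounds than this note shows. Statements on the series, on what has been measured and on what is new or still open speak of the compounds shown alone.

Compound 1 `Cc1ccc(Oc2cccc(CN3CCC(n4cc(C)c(=O)[nH]c4=O)CC3)c2)cc1` is the starting point of this account. In an ADME assay on MRC5 cells (Homo sapiens) for cytotoxicity, read by fluorescence and resazurin assay, with a stated time of 3 days (a higher number here means a weaker inhibitor, a lower number a stronger inhibitor), compound 1 gives only a limit, > 64000 nM, and not a measured number. Compound 2 `Cc1cn(C2CCN(Cc3cncc(Oc4cc(Cl)cc(Cl)c4)c3)CC2)c(=O)[nH]c1=O` likewise returns only a limit in this assay, > 64000 nM. For compound 3 `Cc1cn(C2CCN(Cc3cccc(Oc4ccc(O)cc4)n3)CC2)c(=O)[nH]c1=O` this assay records "not determined" (no result reported), so no number stands beside it. Compound 1 therefore sits at the limit of the assay, together with compound 2, and nothing among the shown values separates the two; the common ground is the limit of > 64000 nM in this assay, at which 2 of the 3 values shown sit.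

The unmeasured compound 4 `Cc1cn(C2CCN(Cc3cccc(Oc4cccc(Cl)c4)c3)CC2)c(=O)[nH]c1=O` differs from compound 1 in one place: 3-chlorophenyl in place of 4-methylphenyl on an oxygen on an aromatic ring. Within the data shown here, no step between measured compounds is available to size such a change in this assay. Given that compound 1 sits at the limit, compound 4 is expected to show a step of a number no higher from compound 1 to compound 4 (the limit leaves the size open) of no size beyond the scatter, if any number is returned at all. Compound 4 is thus estimated at 64000 nM in this assay, within the range from 25000 nM to 150000 nM, with a limit again the most likely report.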

Compound 4, half-maximal inhibitory concentration: 21000 nM
The estimate for compound 4 lay 3.0-fold (0.48 log units) above the measured number; measured number outside the range, below it.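

Among these compounds, with compound 4, a change at this position yields a number for the first time: in this assay, 3-chlorophenyl in place of 4-methylphenyl on an oxygen on an aromatic ring gives an at least 3.0-fold lower number from compound 1 to compound 4 (0.48 log units; beyond the scatter). The earlier compounds shown here offered only limits and an entry with no result, so they could not show that the group on this oxygen can move a compound off the limit. Compound 4 now stands apart from that common ground: the limit of > 64000 nM in this assay, at which 2 of the 4 values shown sit.

The compounds shown leave open whether the step follows from the chlorine itself or from the loss of the methyl group, as 4-chlorophenyl, 3-methylphenyl and plain phenyl on this oxygen do not stand among them. Going by these compounds, how a group of another kind, such as an amine or a carboxylic acid on that ring, would read in this assay also remains open.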